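This account rests on a few compounds, and the source may have more. Where it says the series, first, only, none or still open, it means among the compounds named here.

Measured so far in an ADME assay on HEK-293T cells (Homo sapiens) for inhibition, read by CCK-8 assay, with a stated time of 48 h, tested at 20 uM; a higher number here means more inhibition of growth at the concentration tested, a lower number less inhibition of growth:

Compound 1 `Cc1ccc(S(=O)(=O)Oc2ccccc2/C=C(\C#N)C(=O)Nc2nnc(C)s2)cc1`: 35%
Compound 2 `Cc1ccc(S(=O)(=O)Oc2cccc(/C=C(\C#N)C(=O)Nc3nnc(-c4ccccc4Cl)s3)c2)cc1`: 55%
Compound 3 `N#C/C(=C\c1cccc(NS(=O)(=O)c2ccc(F)cc2)c1)C(=O)Nc1nnc(-c2cccs2)s1`: 29%

Compound 1 (35%) lies within the scatter of compound 3 (29%), so the two cannot be told apart on these numbers. Compound 2 (55%) stands beyond the scatter above compound 1.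

The next compound to be tested is compound 4 `COc1ccc(Cc2nnc(NC(=O)/C(C#N)=C/c3ccccc3OS(=O)(=O)c3ccc(C)cc3)s2)cc1`. It keeps the core of compound 1 and differs from it in one place: 4-methoxyphenyl in place of hydrogen on a saturated chain carbon bound to an aromatic carbon. In words, 4-methoxyphenyl stands in place of hydrogen on a saturated chain carbon bound to an aromatic carbon, which can also be read as methyl to 4-methoxybenzyl.

Within the data shown here, no two measured compounds differ in one place only, so the data give no direct measure of such a change. In this assay a modest rise is expected, of a size close to the scatter, and no change at all would not be a surprise. The expectation stays inside the span set by compound 3 (29%) and compound 2 (55%). The estimated change is a number 6 percentage points higher from compound 1 to compound 4 (within the scatter). For compound 4 the expected value is 41%, with an estimated range from 24% to 58%.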

Compound 4, percent growth inhibition at one concentration: 21%
Beside the measured number, compound 4's estimate is 20 percentage points above it; measured number below the stated range.
By their numbers in this assay, from the lowest: compounds 4, 3 and 1 (each within the scatter of the next, the first and the last beyond it); then compound 2.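

In this assay, among these compounds, 4-methoxyphenyl in place of hydrogen on a saturated chain carbon bound to an aromatic carbon, which also reads as methyl to 4-methoxybenzyl, gives the first change that can be read in one place alone, and the step is downward: a number 14 percentage points lower from compound 1 to compound 4 (beyond the scatter). On the core of compound 1, this position is therefore not indifferent to what stands on it, and here the 4-methoxybenzyl group goes with less growth inhibition at the concentration tested than the methyl group. Nothing measured here bears on the reason for this drop, so the result stands as an observation from a single pair.

As far as these compounds go, whether the drop belongs to the added phenyl ring or to its methoxy group remains open, and an unsubstituted benzyl group, a 4-hydroxybenzyl group or a plain ethyl chain at this place would be needed to separate the two. From the compounds shown here alone, compound 2 and compound 3 differ from the other compounds in more than one place, so steps to them cannot be read, and how this change behaves on their cores also remains open.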